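The compounds below may be only part of what the source reports. "The series", "measured", "known", "first", "only" and "open" are said of these compounds alone.

Among the compounds with values here, compound 1 `COC(=O)Cc1c(C)n(Cc2ccc(-c3cn(CCCCCCCC(=O)NO)nn3)cc2)c2ccc(OC)cc12` is the only compound here with a number: in a functional assay on LNCaP cells (Homo sapiens) for inhibition, read by MTT assay, with a stated time of 72 h (on this read-out lower numbers stand for stronger inhibition and higher numbers for weaker inhibition), compound 1 gives 1530 nM. Compound 2 `Cc1ccc(-c2cc(C(=O)NCCCCCC(=O)NO)nn2-c2ccc(S(N)(=O)=O)cc2)cc1` was run in this assay, but for compound 2 the entry reads "not determined" (no result reported), so no result was reported for it. Within the data shown here, compound 3 `COC(=O)Cc1c(C)n(Cc2ccc(-c3cn(CCCCCC(=O)NO)nn3)cc2)c2ccc(OC)cc12` differs from compound 1 in one place, (hydroxycarbamoyl in place of 2-(hydroxycarbamoyl)ethyl on a saturated chain carbon, five bonds along the chain from an aromatic nitrogen); no measured pair shows this change, so its effect is unknown. Shortening the chain toward the hydroxycarbamoyl end is expected to cost some inhibition in this assay, with a step from compound 1 to compound 3 of a 2.6-fold higher number from compound 1 to compound 3 (0.42 log units; beyond the scatter). Compound 3 is therefore estimated at 4000 nM, between 1500 nM and 12000 nM.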

Compound 3, half-maximal inhibitory concentration: > 20000 nM
Compound 3 gave a limit, no number (the forecaster's own chance of this, stated with the estimate: 10%); middle value at least 5.0-fold (0.69 log units) from the limit.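

Compound 3 gives only a limit in this assay, not a number: the limit of > 20000 nM in this assay, at which 1 of the 3 values shown sits. Hydroxycarbamoyl in place of 2-(hydroxycarbamoyl)ethyl, on a saturated chain carbon, five bonds along the chain from an aromatic nitrogen, brings an at least 13-fold higher number from compound 1 to compound 3 (1.11 log units; beyond the scatter). Within the data shown here, this is the first measured pair for this change, and it shows that in this pair inhibition depends strongly on chain length at this position. The two compounds give no cause for the loss. On these data alone, how a longer chain, or a carboxylic acid in place of the hydroxycarbamoyl end, would read in this assay stays open.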